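Replacing Bromo with Methyl in Compound 1

A few compounds are considered here, and "the series" means these few. Any claim that something is new, unique, unknown or untested is made for them only; others in the source may bear on it.

Among the measured compounds shown here, in a functional assay on THP-1 cells (Homo sapiens) for inhibition, read by sulforhodamine B assay, with a stated time of 48 h (on this read-out lower numbers stand for stronger inhibition and higher numbers for weaker inhibition), compound 1 `COC(=O)[C@@]1(C)C[C@@H](c2coc3ccc(Br)cc3c2=O)N(c2ccccc2)O1` gives 14700 nM as its reading, the lower of the two numbers measured so far. Compound 2 `O=c1c([C@@H]2C[C@H](c3ccccc3)ON2c2ccccc2)coc2ccc(F)cc12` gives 54700 nM as its reading, a higher number by a margin beyond the scatter. These two compounds differ in more than one place, so they offer no single step to reason from. Compound 3 `COC(=O)[C@@]1(C)C[C@@H](c2coc3ccc(C)cc3c2=O)N(c2ccccc2)O1` comes from compound 1 through the change methyl in place of bromo on an aromatic carbon and nothing else: methyl in place of bromo on an aromatic carbon. For the measured compounds named here, no measured pair shows what this swap does in this assay here. No step beyond the scatter is expected, and the estimated step is a 1.4-fold higher number from compound 1 to compound 3 (0.13 log units; within the scatter) on present evidence. Compound 3 is estimated at 20000 nM with an expected range from 8000 nM to 50000 nM in this read-out.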

Compound 3, half-maximal inhibitory concentration: 7300 nM
Beside the measured number, compound 3's estimate is 2.7-fold (0.44 log units) above it; measured number below the stated range.
By their numbers in this assay, from the lowest: compounds 3 and 1 (each within the scatter of the next); then compound 2.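

In this assay, methyl in place of bromo on this aromatic carbon gives a 2.0-fold lower number from compound 1 to compound 3 (0.30 log units; within the scatter) and provides the first single-place step among these compounds. The two groups therefore cannot be told apart at this position, on this core, in this read-out: exchanging one heavy atom for another here leaves the reading within the scatter. Nothing at hand accounts for the two groups reading alike.

Still open, as far as these compounds go, is whether a group of another kind at this place, such as an amine, a carboxylic acid or a longer chain, would shift the number beyond the scatter. The compounds shown also leave open whether methyl and bromo would read alike on the core of compound 2, which differs from compound 1 in more than one place.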